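The source may report more compounds than this note shows. Statements on the series, on what has been measured and on what is new or still open speak of the compounds shown alone.

Compound 1 `CCC(=O)N1CCN(c2cc(NCCN)c3ccccc3n2)CC1` gives in an ADME assay on HEp-2 cells (Homo sapiens) for cytotoxicity, read by CCK-8 assay, with a stated time of 6 days; a lower number here means that less compound is tolerated, a higher number that more compound is tolerated > 100000 nM, which is a limit of the assay.
Compound 2 `NCCNc1cc(N2CCN(C(=O)C3(c4ccccc4)CC3)CC2)nc2ccccc12` gives in this assay > 100000 nM, also a limit of the assay.
Compound 3 `CS(=O)(=O)N1CCN(c2cc(NCCN)c3ccccc3n2)CC1` gives in this assay > 100000 nM, again a limit of the assay.

Going by the values given here, compound 3 therefore stands at the limit of > 100000 nM in this assay, at which 3 of the 3 values shown sit, together with compound 1 and compound 2; no measured compound has a readable number. Compound 4 `NCCNc1cc(N2CCN(C(=O)C3CCCCC3)CC2)nc2ccccc12` differs from compound 3 in one place: cyclohexylcarbonyl in place of methylsulfonyl on an amine nitrogen in a ring. Among the compounds with values here, the only measured steps, a step that the two limits leave unreadable from compound 1 to compound 2 and a step that the two limits leave unreadable from compound 1 to compound 3, each join two limits, so neither shows a size nor a direction that could guide this change. For compound 4 the expected step is a number no higher from compound 3 to compound 4 (the limit leaves the size open), most likely ending once more at a limit. Compound 4 is thus estimated at 100000 nM, between 30000 nM and 300000 nM.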

Compound 4, half-maximal cytotoxic concentration: > 100000 nM
Compound 4: only a limit was reported; the forecaster's own chance of this, stated with the estimate: 80%; the middle value lies on the limit itself.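

The steps from compound 1, compound 2 and compound 3 to compound 4 cannot be read, since each joins two limits of the assay: the limit of > 100000 nM in this assay, at which 4 of the 4 values shown sit. On these data alone, whether any of these changes alters how much compound the cells tolerate stays open.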